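Swapping the amide-side aryl group: methoxy out, fluorine in

This account rests on a few compounds, and the source may have more. Where it says the series, first, only, none or still open, it means among the compounds named here.

Measured so far:
- compound 1, `O=C(CSc1nc(Nc2ccccc2)c2ccccc2n1)Nc1ccccc1Cl`: 9610 nM
- compound 2, `O=C(CSc1nc(Nc2ccccc2)c2ccccc2n1)Nc1cccc(F)c1`: 6790 nM
- compound 3, `COc1cccc(NC(=O)CSc2nc(Nc3ccccc3)c3ccccc3n2)c1`: 19400 nM

In a functional assay on NCI-H1975 cells (Homo sapiens) for inhibition, read by MTT assay, with a stated time of 72 h (on this read-out higher numbers stand for weaker inhibition and lower numbers for stronger inhibition), compound 3 gives the highest number of the three, that is the weakest inhibition. Its nearest neighbour is compound 1, with a 2.0-fold higher number from compound 1 to compound 3 (0.31 log units; beyond the scatter), and its furthest is compound 2, with a 2.9-fold higher number from compound 2 to compound 3 (0.46 log units; beyond the scatter).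

Compound 4, `O=C(CSc1nc(Nc2ccccc2)c2ccccc2n1)Nc1ccc(F)cc1`, differs from compound 3 by 4-fluorophenyl in place of 3-methoxyphenyl on an amide-type nitrogen. The step from compound 2 to compound 3 bears on this, since it exchanged fluoro for methoxy and raised the number; reversing that exchange should lower it again. Where the fluorine sits differs from compound 2, and no measured pair tells what that alone does. Compound 4 is therefore expected to show a 2.6-fold lower number from compound 3 to compound 4 (0.41 log units; beyond the scatter), landing near compound 2. The estimate for compound 4 is 7500 nM, with a range from 3500 nM to 16000 nM.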

Compound 4, half-maximal inhibitory concentration: 16500 nM
Estimate against measurement, compound 4: 2.2-fold (0.34 log units) below, outside the stated range (above it).
By their numbers in this assay, from the lowest: compounds 2, 1, 4 and 3 (each within the scatter of the next, the first and the last beyond it).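

In this assay a fluorine on this aryl group is not enough on its own: the exchange gives a 1.2-fold lower number from compound 3 to compound 4 (0.07 log units; within the scatter) and leaves 4-fluorophenyl level with 3-methoxyphenyl. The place of the fluorine does count, as a 2.4-fold higher number from compound 2 to compound 4 (0.39 log units; beyond the scatter) shows, whereas a 1.7-fold higher number from compound 1 to compound 4 (0.23 log units; within the scatter) stays inside the usual scatter. Nothing available explains why moving the fluorine changes the number.

Still open, on these data alone, is whether moving a methoxy group or a chlorine on this aryl group shifts the number as moving the fluorine does. Also open, as far as these compounds go, is what an amine or a carboxylic acid there would give.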